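Thiophene Replaces the Substituted Phenyl on the Shared Core

This account rests on a few compounds, and the source may have more. Where it says the series, first, only, none or still open, it means among the compounds named here.

Compound 3 `Cc1cc(-c2c(-c3ccc(F)cc3)nc(C(F)(F)F)n2CC[C@@H](O)C[C@@H](O)CC(=O)O)cc(C)c1F` holds the lowest number among the three measured compounds in an assay on microsomes from liver for inhibition of 3-hydroxy-3-methylglutaryl-coenzyme A reductase (Rattus norvegicus) (on this read-out higher numbers stand for weaker inhibition and lower numbers for stronger inhibition), where compound 3 gives 31 nM. Compound 2 `Cc1cc(C)cc(-c2c(-c3ccc(F)cc3)nc(C(F)(F)F)n2CC[C@@H](O)C[C@@H](O)CC(=O)O)c1` is its nearest neighbour, and compound 2 gives 38 nM; the step of a 1.2-fold lower number from compound 2 to compound 3 (0.09 log units; within the scatter) lies within the scatter, so no order between these two can be claimed. Compound 1 `Cc1ccc(-c2c(-c3ccc(F)cc3)nc(C(F)(F)F)n2CC[C@@H](O)C[C@@H](O)CC(=O)O)cc1` stands furthest away, and compound 1 gives 750 nM.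

Compound 4 `O=C(O)C[C@H](O)C[C@H](O)CCn1c(C(F)(F)F)nc(-c2ccc(F)cc2)c1-c1cccs1` differs from compound 3 in a single place: thiophen-2-yl in place of 4-fluoro-3,5-dimethylphenyl on an aromatic carbon.

Among the measured compounds shown here, no measured step exchanges the whole six-membered ring for a five-membered one, so the evidence is indirect. The steps of a 20-fold lower number from compound 1 to compound 2 (1.30 log units; beyond the scatter) and a 24-fold lower number from compound 1 to compound 3 (1.38 log units; beyond the scatter) show that going from 4-methylphenyl to 3,5-dimethylphenyl or to 4-fluoro-3,5-dimethylphenyl lowered the number by a large amount. Thiophen-2-yl carries neither the two methyl groups nor the fluorine that distinguish compound 3 from compound 1, so the account expects a large step toward higher numbers in this assay, likely reaching or passing the region of compound 1.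

Compound 4 is therefore estimated at 600 nM, with a range from 150 nM to 2500 nM, which corresponds to an expected step of a 19-fold higher number from compound 3 to compound 4 (1.29 log units; beyond the scatter).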

Compound 4, half-maximal inhibitory concentration: 215 nM
Estimate against measurement, compound 4: 2.8-fold (0.45 log units) above, and the stated range covers the measured number.
By their numbers in this assay, from the lowest: compounds 3 and 2 (each within the scatter of the next); then compound 4; then compound 1.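

In this assay this position, on an aromatic carbon of the five-membered aromatic ring with 2 nitrogen, also accepts a five-membered aromatic ring with 1 hetero atom, and thiophen-2-yl gives an intermediate number among the four compounds. It falls short of the two dimethyl-substituted phenyl groups (a 6.9-fold higher number from compound 3 to compound 4 (0.84 log units; beyond the scatter); a 5.7-fold higher number from compound 2 to compound 4 (0.75 log units; beyond the scatter)), yet it still improves on 4-methylphenyl (a 3.5-fold lower number from compound 1 to compound 4 (0.54 log units; beyond the scatter)). The earlier compounds showed only six-membered rings and could suggest that a group without the two methyl groups would sit at the high end of the series, but thiophen-2-yl has no methyl group or fluorine and still has a lower number than compound 1, while no measurement here explains its place in this order.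

The compounds shown leave open how an unsubstituted phenyl ring would compare with thiophen-2-yl, and so whether the 4-methyl group of compound 1 or the change of ring accounts for the gap between compound 1 and compound 4. They also leave open whether two methyl groups on the thiophene, as in 4,5-dimethylthiophen-2-yl, or a different attachment or hetero atom, as in thiophen-3-yl or furan-2-yl, would move the number toward that of compound 3.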